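Swapping the sulfonyl aryl group: stability expected to hold

This account rests on a few compounds, and the source may have more. Where it says the series, first, only, none or still open, it means among the compounds named here.

For the measured compounds named here, compound 1 `O=C(NCc1ccc(F)cc1)c1ccc(N2CCN(S(=O)(=O)c3ccccc3C(F)(F)F)CC2)nn1` is one of two compounds measured in an ADME assay on microsomes from liver (Mus musculus) for metabolic stability, read by LC-MS, using NADPH, tested at 10 uM; a lower number here means that the compound disappears faster, a higher number that the compound lasts longer. Compound 1 gives 0.517 h, the higher of the two numbers, while compound 2 `O=C(NCc1ccccc1)c1ccc(N2CCN(S(=O)(=O)c3cccc(Cl)c3Cl)CC2)nn1` gives 0.233 h, a gap beyond the usual scatter. Compound 3 `Cc1cc(F)ccc1S(=O)(=O)N1CCN(c2ccc(C(=O)NCc3ccc(F)cc3)nn2)CC1` has not yet been measured. It differs from compound 1 in one place: 4-fluoro-2-methylphenyl in place of 2-(trifluoromethyl)phenyl on a sulfonyl sulfur. Going by the values given here, no measured pair shows this kind of change, so only a modest step is expected, leaning downward but quite possibly within the scatter: a 1.3-fold lower number from compound 1 to compound 3 (0.11 log units; within the scatter). Compound 3 is estimated at 0.4 h, within 0.2 h to 0.8 h.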

Compound 3, half-life: 0.25 h
Estimate against measurement, compound 3: 1.6-fold (0.20 log units) above, within the range that was stated.
By their numbers in this assay, from the lowest: compounds 2 and 3 (each within the scatter of the next); then compound 1.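

The aryl group on the sulfonyl sulfur matters in this assay: 4-fluoro-2-methylphenyl in place of 2-(trifluoromethyl)phenyl gives a 2.1-fold lower number from compound 1 to compound 3 (0.32 log units; beyond the scatter), so this position does not tolerate every swap without a cost in half-life. For the compounds shown here, this is the first pair that differs in this one place alone. Nothing given here explains the drop.

The new group differs from the old one in more than one feature, so the pair cannot show which feature carries the step. From the compounds shown here alone, how a plain phenyl, or an aryl ring bearing a nitrile or a methoxy group, would behave at this position remains open.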